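Dropping the fluoro from compound 2

The compounds below may be only part of what the source reports. "The series", "measured", "known", "first", "only" and "open" are said of these compounds alone.

For the measured compounds named here, in a functional assay on MCF7 cells (Homo sapiens) for inhibition, read by MTT assay, with a stated time of 72 h (a lower number here means a stronger inhibitor, a higher number a weaker inhibitor), compound 1 `COc1ccc(-c2nnc(SCCCN3CCN(c4nc5ccccc5s4)CC3)o2)cc1` gives 171000 nM and compound 2 `Fc1ccc(-c2nnc(SCCCN3CCN(c4nc5ccccc5s4)CC3)o2)cc1` gives 84100 nM, the lower of the two numbers so far. Compound 3 `c1ccc(-c2nnc(SCCCN3CCN(c4nc5ccccc5s4)CC3)o2)cc1` differs from compound 2 by hydrogen in place of fluoro on an aromatic carbon, with hydrogen in place of fluoro on an aromatic carbon. Going by the values given here, only one measured step bears on this change: a 2.0-fold lower number from compound 1 to compound 2 (0.31 log units; beyond the scatter), a modest step at that same aromatic carbon. A small rise is therefore expected in this assay, probably not beyond the scatter, and the expected step is a 1.3-fold higher number from compound 2 to compound 3 (0.12 log units; within the scatter). For compound 3 the estimate is 110000 nM, with an expected range of 55000 nM to 220000 nM.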

Compound 3, half-maximal inhibitory concentration: 76900 nM
Compound 3: the middle estimate sits 1.4-fold (0.16 log units) above what was measured; low and high end bracket the measured number.
By their numbers in this assay, from the lowest: compounds 3 and 2 (each within the scatter of the next); then compound 1.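

In this assay hydrogen and fluoro on this aromatic carbon cannot be told apart, with a 1.1-fold lower number from compound 2 to compound 3 (0.04 log units; within the scatter) as the step from 4-fluorophenyl to phenyl. Hydrogen in place of methoxy gives a 2.2-fold lower number from compound 1 to compound 3 (0.35 log units; beyond the scatter) and runs the same way as the earlier fluoro step, so both steps beyond the scatter at this position start from compound 1. No evidence at hand accounts for this.

From the compounds shown here alone, whether an amine, a carboxylic acid or a nitrile on this carbon would shift the number beyond the scatter stays open. So does whether any group here can give numbers well under those of compound 2 and compound 3.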